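The compounds below may be only part of what the source reports. "The series", "measured", "known", "first", "only" and "open" are said of these compounds alone.

Measured so far:
compound 1 `CCCSc1nc(N/N=C/c2cccnc2)c2nnn(Cc3ccccc3)c2n1`: > 64000 nM
compound 2 `CCCSc1nc(N/N=C(\C)c2ccccc2O)c2nnn(Cc3cccc(Cl)c3)c2n1`: 13000 nM

In a functional assay on ECa-109 cells (Homo sapiens) for antiproliferative activity, read by MTT assay, with a stated time of 72 h (on this read-out higher numbers stand for weaker inhibition and lower numbers for stronger inhibition), compound 1 gives > 64000 nM, and this is a limit of the assay rather than a number. Where compound 1 stands is therefore set only by the limit of > 64000 nM in this assay, at which 1 of the 2 values shown sits. Compound 2 gives 13000 nM. Compound 3 `CCCSc1nc(N/N=C/c2c(O)ccc3ccccc23)c2nnn(Cc3ccccc3)c2n1` differs from compound 1 in one place: 2-hydroxynaphthalen-1-yl in place of pyridin-3-yl on a carbon with a double bond to nitrogen. Among the compounds with values here, no step between two measured compounds is available to set the size of such a change. The step of an at least 4.2-fold lower number from compound 1 to compound 3 (0.63 log units; beyond the scatter) is nonetheless expected to run toward stronger inhibition, since compound 2 reaches 13000 nM. Compound 3 is estimated at 15000 nM, with a range from 4000 nM to 60000 nM.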

Compound 3, half-maximal inhibitory concentration: 9290 nM
Compound 3: the middle estimate sits 1.6-fold (0.21 log units) above what was measured, and the stated range covers the measured number.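

In this assay, the change of 2-hydroxynaphthalen-1-yl in place of pyridin-3-yl on a carbon with a double bond to nitrogen gives an at least 6.8-fold lower number from compound 1 to compound 3 (0.83 log units; beyond the scatter), so this one place alone can move the read-out. The earlier pair differed in more than one place and could not show that. Compound 1 stands at a limit, not a number, so the step gives only a minimum size: the limit of > 64000 nM in this assay, at which 1 of the 3 values shown sits.

From the compounds shown here alone, whether the hydroxyl or the second ring matters stays open, since the entering group brings both. A plain naphthalen-1-yl, or one carrying an amine instead of the hydroxyl, would separate them.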